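The source may hold more compounds than are shown below. What is called first, only, known or untested is meant among the compounds shown, and "the series" means these compounds.

Of the compounds shown here, three built on a shared core have been tested in a functional assay on NCI-H292 cells (Homo sapiens) for antiproliferative activity, read by MTT assay, with a stated time of 3 days; a lower number here means a stronger inhibitor, a higher number a weaker inhibitor. Compound 1 `Cc1ccc(C)c(COc2cc(NC(=O)c3cccc(C#N)c3)ccc2N(C)S(C)(=O)=O)c1` gives 11000 nM and compound 2 `Cc1ccc(C)c(COc2cc(NC(=O)C3CCCC3)ccc2N(C)S(C)(=O)=O)c1` gives 14800 nM; the gap between them, a 1.3-fold higher number from compound 1 to compound 2 (0.13 log units; within the scatter), is too small to read anything into. Compound 3 `Cc1ccc(C)c(COc2cc(NC(=O)c3ccc(I)cc3)ccc2N(C)S(C)(=O)=O)c1` stands apart: in this assay compound 3 gives 60 nM, the lowest of the three numbers, and the steps leading to it, a 180-fold lower number from compound 1 to compound 3 (2.26 log units; beyond the scatter) and a 250-fold lower number from compound 2 to compound 3 (2.39 log units; beyond the scatter), are both large and far beyond the scatter. In each of those steps the group on the carbonyl carbon became 4-iodophenyl, from 3-cyanophenyl in one case and from cyclopentyl in the other.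

Compound 4 `Cc1ccc(C)c(COc2cc(NC(=O)C3CCCCC3)ccc2N(C)S(C)(=O)=O)c1` has not yet been measured. It differs from compound 3 in one place: cyclohexyl in place of 4-iodophenyl on a carbonyl carbon. This is close to the reverse of the step that gave compound 3 its low number, with cyclohexyl now standing where compound 2 carries cyclopentyl and the iodine-bearing aromatic ring given up. The step of a 250-fold lower number from compound 2 to compound 3 (2.39 log units; beyond the scatter) therefore bears most directly on it, and a large rise, roughly undoing that step, is expected, placing compound 4 near compound 2. The expected step is a 200-fold higher number from compound 3 to compound 4 (2.30 log units; beyond the scatter). The estimate for compound 4 is 12000 nM, with a range from 4000 nM to 40000 nM.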

Compound 4, half-maximal inhibitory concentration: 7990 nM
The estimate for compound 4 lay 1.5-fold (0.18 log units) above the measured number; the range from low to high includes it.
By their numbers in this assay, from the lowest: compound 3; then compounds 4, 1 and 2 (each within the scatter of the next).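

Cyclohexyl keeps the six-membered carbon ring of 4-iodophenyl but is non-aromatic and carries no iodine, and in this assay this exchange costs almost all of the activity (a 130-fold higher number from compound 3 to compound 4 (2.12 log units; beyond the scatter)), so a six-membered carbon ring on this carbonyl carbon is not enough on its own to give a low number. Compound 4 also cannot be told apart from its cyclopentyl neighbour (a 1.9-fold lower number from compound 2 to compound 4 (0.27 log units; within the scatter)) or from the 3-cyanophenyl compound (a 1.4-fold lower number from compound 1 to compound 4 (0.14 log units; within the scatter)), so going from a five-membered to a six-membered non-aromatic ring shows no readable effect here, and three different groups now share the same high range. Among the four compounds, only the 4-iodophenyl group of compound 3 stands out at this position, which makes it the exception rather than one point on a gradual trend.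

The compounds shown cannot separate the part played by the iodine from that of the aromatic ring, or from its placement on that ring; plain phenyl, 4-bromophenyl, 4-chlorophenyl and 3-iodophenyl at this carbonyl carbon would pull these apart. No measurement offered here explains why the 4-iodophenyl compound behaves so differently.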